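A few compounds are considered here, and "the series" means these few. Any claim that something is new, unique, unknown or untested is made for them only; others in the source may bear on it.

Measured compounds:
compound 1, `COc1ccc(-c2cn3ccnc3c(-c3ccc4ncn(C5CCCCC5)c4c3)n2)cc1`, 89.2%
compound 2, `CC(=O)c1ccc(-c2cn3ccnc3c(-c3ccc4ncn(C5CCCCC5)c4c3)n2)cc1`, 3.43%

Both were tested in a functional assay on M14 cells (Homo sapiens) for inhibition, read by sulforhodamine B assay, with a stated time of 48 h, tested at 10 uM; on this read-out higher numbers stand for more inhibition at the one concentration tested (going by the name of the read-out) and lower numbers for less inhibition. Compound 2 stands lowest of the two numbers; its nearest neighbour is compound 1, which lies higher by a margin beyond the scatter, as the step of a number 85.8 percentage points lower from compound 1 to compound 2 (beyond the scatter) shows. Compound 3, `Clc1ccc(-c2cn3ccnc3c(-c3ccc4ncn(C5CCCCC5)c4c3)n2)cc1`, has not been measured. It differs from compound 2 in one place: chloro in place of acetyl on an aromatic carbon. The exchange sits on an aromatic carbon of a six-membered aromatic ring of carbon only, para to a large group.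

Within the data shown here, no measured step exchanges acetyl for chloro, so no measured pair bears directly on this change. Among the measured compounds shown here, the one measured step, a number 85.8 percentage points lower from compound 1 to compound 2 (beyond the scatter), shows only that a change at this same place can move the number across nearly the whole range; it does not say where chloro will fall. The estimate for compound 3 is therefore broad. In this assay compound 3 is expected to give about 45%, within a range from 5% to 88%, meaning an expected step of a number 41.6 percentage points higher from compound 2 to compound 3 (beyond the scatter), while a number close to compound 2 remains possible.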

Compound 3, a percentage reported as inhibition, at one concentration (the size of the read-out at that concentration, not a potency): 10%
Beside the measured number, compound 3's estimate is 35 percentage points above it; the range from low to high includes it.
By their numbers in this assay, from the lowest: compounds 2 and 3 (each within the scatter of the next); then compound 1.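

In this assay, chloro on this aromatic carbon, para to a large group, does not keep the high number of the methoxy compound, as the step of a number 79.2 percentage points lower from compound 1 to compound 3 (beyond the scatter) shows. Exchanging acetyl for chloro gives a number 6.6 percentage points higher from compound 2 to compound 3 (within the scatter), so the low number does not depend on what acetyl alone brings among these compounds: chloro has no double bond outside aromatic rings and no hydrogen-bond acceptor, yet 4-chlorophenyl and 4-acetylphenyl cannot be told apart here. Of the three compounds, only compound 1, with methoxy, stands high, and the two large steps now set it apart from both of the others, where before there was a single contrast.

Nothing given here explains why methoxy stands apart from acetyl and chloro.

On these data alone, it remains open whether the high number belongs to methoxy alone or would also appear with a hydroxyl, an ethoxy group or a dimethylamino group at this place. Also open, as far as these compounds go, is whether a methoxy group elsewhere on the same aromatic ring, or a fluoro or methyl group at this place, would fall with compound 1 or with the other two.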